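This account rests on a few compounds, and the source may have more. Where it says the series, first, only, none or still open, it means among the compounds named here.

Among the measured compounds shown here, compound 2 `Cn1ccc2ccc(-c3cc(Nc4cnccc4C(=O)NC4CCNC(=O)C4)cc4nccnc34)cc21` gives in an assay on lysate for inhibition of 6-phosphofructo-2-kinase/fructose-2,6-bisphosphatase 3 (Homo sapiens), with stated times of 0.5 min and 45 min (on this read-out lower numbers stand for stronger inhibition and higher numbers for weaker inhibition), a value of 56500 nM, the highest of the two numbers measured so far. Its nearest neighbour, compound 1 `Cn1cc(NC(=O)c2ccncc2Nc2cc(-c3ccc4ccn(C)c4c3)c3nccnc3c2)cn1`, gives 26500 nM in this assay, and the step of a 2.1-fold higher number from compound 1 to compound 2 (0.33 log units; beyond the scatter), a change of 2-oxopiperidin-4-yl in place of 1-methyl-1H-pyrazol-4-yl on an amide-type nitrogen, is the only one measured. Compound 3 `Cn1ccc2ccc(-c3cc(Nc4cnccc4C(=O)NCC4COCCN4)cc4nccnc34)cc21` differs from compound 2 by (morpholin-3-yl)methyl in place of 2-oxopiperidin-4-yl on an amide-type nitrogen. For the measured compounds named here, the measured step touches the same amide-type nitrogen, but with a different pair of groups; no compound bearing (morpholin-3-yl)methyl has been measured, so the direction of this change is unknown. Given the modest size of the one known step, compound 3 is expected to stay near compound 2, with an expected step of a 1.3-fold lower number from compound 2 to compound 3 (0.10 log units; within the scatter). Compound 3 is therefore estimated at 45000 nM, with a likely range from 15000 nM to 130000 nM.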

Compound 3, half-maximal inhibitory concentration: 41700 nM
The estimate for compound 3 lay 1.1-fold (0.03 log units) above the measured number; the measured number falls inside the stated range.
By their numbers in this assay, from the lowest: compounds 1, 3 and 2 (each within the scatter of the next, the first and the last beyond it).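

In this assay, (morpholin-3-yl)methyl on the amide-type nitrogen cannot be told apart from 2-oxopiperidin-4-yl, with a 1.4-fold lower number from compound 2 to compound 3 (0.13 log units; within the scatter) in that exchange, or from 1-methyl-1H-pyrazol-4-yl, with a 1.6-fold higher number from compound 1 to compound 3 (0.20 log units; within the scatter) in that one. At the same count of heavy atoms, a six-membered non-aromatic ring with two hetero atoms thus replaces one with a single hetero atom and a double bond outside aromatic rings, and the number stays within the scatter, although compound 1 and compound 2 lie beyond the scatter of each other. No measurement at hand explains these numbers. As far as these compounds go, whether a primary amine, a carboxylic acid or a longer chain on this nitrogen would give a number clearly lower than those of compound 1, compound 2 and compound 3 remains open. Also open, from the compounds shown here alone, is whether a change to the shared core would move the number further than these exchanges do.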